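Adding a methyl to the sulfur-bound chain

The source may hold more compounds than are shown below. What is called first, only, known or untested is meant among the compounds shown, and "the series" means these compounds.

Compound 1 `CC(C)COC(=O)N1CCC(Oc2ncnc3c2CCN3c2ccc(S(C)(=O)=O)cc2F)CC1` gives 25.1 nM in a functional assay on CHO-K1 cells for agonist activity at Glucose-dependent insulinotropic receptor (Homo sapiens), read by a luciferase reporter, with a stated time of 5 h; a lower number here means that less compound is needed, a higher number that more compound is needed for the effect. Compound 2 `CC(C)(C)COC(=O)N1CCC(Oc2ncnc3c2CCN3c2ccc(S(C)(=O)=O)cc2F)CC1` carries methyl in place of hydrogen on a saturated chain carbon bound to three saturated chain carbons and in this assay compound 2 gives 39.8 nM; the step is a 1.6-fold higher number from compound 1 to compound 2 (0.20 log units; within the scatter). Compound 3 `CCSC(=O)N1CCC(Oc2ncnc3c2CCN3c2ccc(S(C)(=O)=O)cc2F)CC1` differs from compound 1 by ethylsulfanyl in place of isobutoxy on a carbonyl carbon, and in this assay compound 3 gives 31.6 nM, a step of a 1.3-fold higher number from compound 1 to compound 3 (0.10 log units; within the scatter). Compound 4 `CC(C)SC(=O)N1CCC(Oc2ncnc3c2CCN3c2ccc(S(C)(=O)=O)cc2F)CC1` has not been measured; it differs from compound 3 by methyl in place of hydrogen on a saturated chain carbon bound to a saturated chain carbon and a sulfur. This is the same kind of change as from compound 1 to compound 2, but the place differs: there the carbon was bound to three saturated chain carbons, here to a saturated chain carbon and a sulfur. Because a 1.6-fold higher number from compound 1 to compound 2 (0.20 log units; within the scatter) stayed within the scatter, a similarly small step a 1.3-fold higher number from compound 3 to compound 4 (0.10 log units; within the scatter) is expected. Compound 4 is expected to give 40 nM, with a range from 15 nM to 110 nM.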

Compound 4, half-maximal effective concentration: 10 nM
Estimate against measurement, compound 4: 4.0-fold (0.60 log units) above; the measured number lies below the stated range.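

On the sulfur-bound chain, the added methyl means less compound is needed in this assay (a 3.2-fold lower number from compound 3 to compound 4 (0.50 log units; beyond the scatter)), and isopropylsulfanyl also stands apart from the two oxygen-bound chains (a 2.5-fold lower number from compound 1 to compound 4 (0.40 log units; beyond the scatter)) and (a 4.0-fold lower number from compound 2 to compound 4 (0.60 log units; beyond the scatter)). Going by these compounds alone, each core supplies only a single pair, so this cannot explain the difference or predict how the methyl would act on another chain. Still, the same methyl change did not carry over as a fixed step from one core to the other: the same change on two cores in this assay, a 1.6-fold higher number (0.20 log units; within the scatter) from compound 1 to compound 2 and a 3.2-fold lower number (0.50 log units; beyond the scatter) from compound 3 to compound 4, 5.0-fold (0.70 log units) apart, beyond the scatter of two such steps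

The compounds shown leave open how a larger group on the sulfur, such as tert-butyl or a longer chain, would compare. Also open, on these data alone, is how isopropoxy, the oxygen-bound counterpart of isopropylsulfanyl, would compare.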